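The source may report more compounds than this note shows. Statements on the series, on what has been measured and on what is new or still open speak of the compounds shown alone.

Measured so far:
- compound 1 `CC1CCN(c2c(S(=O)(=O)c3cccc(C#N)c3)cnc3cc(F)ccc23)CC1` gives 92% in an assay on isolated protein for displacement of a labelled ligand from metabotropic glutamate receptor 5 (Homo sapiens), with a stated time of 60 min, tested at 1 uM; on this read-out lower numbers stand for less inhibition and higher numbers for more inhibition at the one concentration tested (going by the name of the read-out)
- compound 2 `CC1CCN(c2c(S(=O)(=O)c3ccc(Cl)cc3)cnc3cc(F)ccc23)CC1` gives 90% in this assay
- compound 3 `CC1CCN(c2c(S(=O)(=O)c3ccc(C#N)cc3)cnc3cc(F)ccc23)CC1` gives 83% in this assay

All three share one core and differ only in the aryl group on the sulfonyl sulfur. Compound 3 has the lowest of the three numbers, but this means little: its nearest neighbour is compound 2, with a number 7 percentage points lower from compound 2 to compound 3 (within the scatter), and its furthest is compound 1, with a number 9 percentage points lower from compound 1 to compound 3 (within the scatter), both within the scatter. The remaining pair, a number 2 percentage points lower from compound 1 to compound 2 (within the scatter), is also within the scatter. Taken together, swapping 3-cyanophenyl, 4-chlorophenyl and 4-cyanophenyl on the sulfonyl sulfur has not moved the read-out beyond what repeated measurements would show.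

Compound 4 `CC1CCN(c2c(S(=O)(=O)c3cc(F)cc(F)c3)cnc3cc(F)ccc23)CC1` continues this sequence of aryl changes at the same position: 3,5-difluorophenyl in place of 4-cyanophenyl on a sulfonyl sulfur. Every measured step that bears on it is a change of the aryl group on the sulfonyl sulfur, and every one of them was within the scatter. On that basis a step of a number 3 percentage points higher from compound 3 to compound 4 (within the scatter) is expected in this assay, that is, no change beyond the scatter. The estimate for compound 4 is therefore 86%, with a range from 70% to 96%.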

Compound 4, a percentage reported as inhibition, at one concentration (the size of the read-out at that concentration, not a potency): 77%
Compound 4: middle estimate off by 9 percentage points, on the high side; measured number inside the range.
By their numbers in this assay, from the lowest: compounds 4, 3, 2 and 1 (each within the scatter of the next, the first and the last beyond it).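

Going by these compounds alone, with 3,5-difluorophenyl on the sulfonyl sulfur, this assay gives the first steps at this position that lie beyond the scatter, both of them modest: a number 13 percentage points lower from compound 2 to compound 4 (beyond the scatter) and a number 15 percentage points lower from compound 1 to compound 4 (beyond the scatter) in the series. The aryl group on the sulfonyl sulfur can therefore shift the read-out, at least for these pairs, whereas the earlier aryl changes had all stayed within the scatter. The pattern is not a clean separation of 3,5-difluorophenyl from the other aryl groups, since compound 3 goes against it: a number 6 percentage points lower from compound 3 to compound 4 (within the scatter) stays within the scatter, and 4-cyanophenyl cannot be told apart from 3,5-difluorophenyl here. No available evidence accounts for the difference between these aryl groups.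

The compounds shown leave open whether a single fluorine on the phenyl ring gives a read-out like that of compound 4 or like that of compound 1, and how an unsubstituted phenyl would compare. As far as these compounds go, it also remains open whether a methoxy-substituted phenyl, a pyridine ring or a saturated cyclohexyl group on the sulfonyl sulfur would keep the read-out in the same range.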